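The compounds below may be only part of what the source reports. "The series", "measured", "known", "first", "only" and "open" are said of these compounds alone.

Compound 1 `Cc1ccc(C(=O)NNC(=S)Nc2csc(-c3ccccc3)c2)cc1` and compound 2 `COc1ccc(C(=O)NNC(=S)Nc2csc(-c3ccccc3)c2)cc1` share one core, and compound 3 `Cc1ccc(-c2nnc(Nc3csc(-c4ccccc4)c3)s2)cc1` and compound 4 `COc1ccc(-c2nnc(Nc3csc(-c4ccccc4)c3)s2)cc1` share another; the difference between the two cores is not broken down here. In a functional assay on Hs 683 cells (Homo sapiens) for inhibition, read by colorimetric assay and MTT assay, with a stated time of 72 h (on this read-out higher numbers stand for weaker inhibition and lower numbers for stronger inhibition), compound 1 gives 37000 nM, and in this assay compound 2 gives 35000 nM. The change between them, (methoxy in place of methyl on an aromatic carbon), yields a 1.1-fold lower number from compound 1 to compound 2 (0.02 log units; within the scatter), so the two values cannot be told apart. For compound 3 the entry in this assay reads "not determined" (no result reported), so there is no value to anchor the second core. For the measured compounds named here, the change from compound 3 to compound 4 is methoxy in place of methyl on an aromatic carbon, the same change as the one from compound 1 to compound 2, made on the same place. Because that earlier change gave a 1.1-fold lower number from compound 1 to compound 2 (0.02 log units; within the scatter), a step of similar, small size is expected for compound 4 relative to compound 3, but the absence of a value for compound 3 leaves the level of the second core open. Compound 4 is therefore estimated at 30000 nM in this assay, with a wide range from 6000 nM to 150000 nM.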

Compound 4, half-maximal inhibitory concentration: 5000 nM
Estimate against measurement, compound 4: 6.0-fold (0.78 log units) above, outside the stated range (below it).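

In this assay, for the compounds shown here, compound 3 stands as "not determined" (no result reported) while compound 4 gives 5000 nM, so no step from compound 3 to compound 4 can be read. The compounds shown leave open whether 4-methylphenyl to 4-methoxyphenyl changes the number on this core as little as on the core of compound 1. Nothing shown bears on a cause for the value of compound 4.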